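Removing the ortho chloro from a weak cytotoxic chalcone

The compounds below may be only part of what the source reports. "The series", "measured", "known", "first", "only" and "open" are said of these compounds alone.

For the measured compounds named here, in a functional assay on PC-3 cells (Homo sapiens) for cytotoxicity, read by MTT assay (on this read-out lower numbers stand for stronger inhibition and higher numbers for weaker inhibition), compound 3 `Cc1cccc(Nc2nc(C)c(C(=O)/C=C/c3ccccc3Cl)s2)c1` gives 22200 nM, the only numeric value among the three measured compounds. Compound 1 `COc1ccc(/C=C/C(=O)c2sc(Nc3ccc(Cl)cc3)nc2C)cc1` reaches only the limit > 25000 nM in this assay. Compound 2 `COc1cc(/C=C/C(=O)c2sc(Nc3ccc(Cl)cc3)nc2C)cc(OC)c1OC` likewise stops at the limit > 25000 nM. Two of three results therefore sit at the limit of > 25000 nM in this assay, at which 2 of the 3 values shown sit, which leaves compound 3 standing as the sole point fixed by a number, close to that limit itself.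

Compound 4 `Cc1cccc(Nc2nc(C)c(C(=O)/C=C/c3ccccc3)s2)c1` differs by hydrogen in place of chloro on an aromatic carbon. Going by the values given here, no measured step bears on this change, so the expected step from compound 3 to compound 4 is a 1.3-fold higher number from compound 3 to compound 4 (0.10 log units; within the scatter), not beyond the scatter and open in direction. Compound 4 is estimated at 28000 nM, within 12000 nM to 60000 nM, with a fair chance that this assay again reports only a limit.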

Compound 4, half-maximal inhibitory concentration: 11700 nM
Beside the measured number, compound 4's estimate is 2.4-fold (0.38 log units) above it, and the stated range ends above it.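

In this assay, for the compounds shown here, the one step at this position (a 1.9-fold lower number from compound 3 to compound 4 (0.28 log units; within the scatter)) shows that the change from 2-chlorophenyl to phenyl does not separate compound 3 from compound 4. Compound 4 also returns a number rather than a limit, so a measurable value here does not depend on the chloro. Nothing shown bears on the cause of this step.

Still open, going by these compounds, is whether another group at this position, such as a fluoro, a nitrile, an amine or a carboxylic acid, would move the number beyond the scatter. The compounds shown also leave open whether any group here could bring potency far from this weak range.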